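The source may hold more compounds than are shown below. What is called first, only, known or untested is meant among the compounds shown, and "the series" means these compounds.

The measured compounds in an assay on LM cells for displacement of a labelled ligand from Neuropeptide Y receptor type 5 (Homo sapiens); on this read-out lower numbers stand for stronger inhibition and higher numbers for weaker inhibition:

Compound 1, `Fc1ccc(C2(c3ccc(F)cc3)CNC(c3ccc(C(F)(F)F)cc3)=N2)cc1`, gives 160 nM.
Compound 2, `O=Cc1cccc(C2=NC(c3ccc(F)cc3)(c3ccc(F)cc3)CN2)c1`, gives 8.7 nM.
Compound 3, `CN(C)c1cccc(C2=NC(c3ccc(F)cc3)(c3ccc(F)cc3)CN2)c1`, gives only a limit of the assay, > 1000 nM.

Compound 2 stands at the lowest of the two numbers in this assay; the nearest is compound 1, and the gap from compound 2 at 8.7 nM to compound 1 at 160 nM is beyond the usual scatter. Compound 3 sits at the limit of the assay, and this is recorded in the limit of > 1000 nM in this assay, at which 1 of the 3 values shown sits.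

Compound 4, `Fc1ccc(C2(c3ccc(F)cc3)CNC(c3ccncc3)=N2)cc1`, has not yet been measured. It differs from compound 2 in one place: pyridin-4-yl in place of 3-formylphenyl on a carbon with a double bond to nitrogen.

Among the measured compounds shown here, only one measured step starts from compound 2 and changes the same ring: an at least 110-fold higher number from compound 2 to compound 3 (2.06 log units; beyond the scatter). Replacing the formyl group there cost a great deal. The change to compound 4 also removes the formyl group, this time with the whole 3-formylphenyl ring giving way to pyridin-4-yl, so a step toward a higher number in this assay is expected, although its size is uncertain since no other change at this position was measured.

Compound 4 is therefore expected to give 300 nM in this assay, with a range from 50 nM to 2000 nM, which means an expected step of a 34-fold higher number from compound 2 to compound 4 (1.54 log units; beyond the scatter).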

Compound 4, half-maximal inhibitory concentration: 160 nM
Compound 4: the middle estimate sits 1.9-fold (0.27 log units) above what was measured; the measured number falls inside the stated range.
By their numbers in this assay, from the lowest: compound 2; then compounds 1 and 4 (each within the scatter of the next). At a limit, above all of these: compound 3.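

In this assay, pyridin-4-yl in place of 3-formylphenyl on the carbon with a double bond to nitrogen gives an 18-fold higher number from compound 2 to compound 4 (1.26 log units; beyond the scatter), so this change costs a large step, yet it leaves a readable number, and compound 1 gives 160 nM while compound 4 gives 160 nM, the same printed value with a different ring at this place. The other new comparison gives an at least 6.2-fold lower number from compound 3 to compound 4 (0.79 log units; beyond the scatter), which shows that at this place pyridin-4-yl stands clearly on the lower side of 3-(dimethylamino)phenyl, whose compound gave no number at all. The value of compound 3 is a limit of the assay and not a number, so this step has only a bound for its size: the limit of > 1000 nM in this assay, at which 1 of the 4 values shown sits.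

The compounds shown leave open whether the low number of compound 2 belongs to the formyl group itself or to the phenyl ring that carries it. On these data alone, it also remains open whether a nitrile, a carboxylic acid or a primary amide in place of the formyl group would keep that number or lose it.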